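Bromo in place of methoxy on an aromatic carbon

A few compounds are considered here, and "the series" means these few. Any claim that something is new, unique, unknown or untested is made for them only; others in the source may bear on it.

In an ADME assay on HEK293 cells (Homo sapiens) for cytotoxicity, read by MTT assay, with a stated time of 72 h (on this read-out lower numbers stand for stronger inhibition and higher numbers for weaker inhibition), compound 1 `COc1ccc2[nH]cc(CCCN3CCN(C(=O)CN4CCN(C(=O)c5ccc(Cl)cc5)CC4)CC3)c2c1` gives 117000 nM. Compound 2 `COc1cccc(C(=O)N2CCN(CC(=O)N3CCN(CCCc4c[nH]c5ccc(OC)cc45)CC3)CC2)c1` gives > 200000 nM, which is a limit of the assay and not a number. Compound 3 `COc1ccc2[nH]cc(CCCN3CCN(C(=O)CN4CCN(C(=O)c5cccc(Br)c5)CC4)CC3)c2c1` differs from compound 2 by bromo in place of methoxy on an aromatic carbon. Among the compounds with values here, one measured step bears on this change: an at least 1.7-fold higher number from compound 1 to compound 2 (0.23 log units; that floor lies within the scatter). Within the data shown here, in that step the 3-methoxyphenyl group of compound 2 also replaced another group, so it is the only guide available. The expectation therefore leans on compound 1 at 117000 nM, which carries a halogen-bearing ring and gives a number in this assay. The expected change is an at least 1.6-fold lower number from compound 2 to compound 3 (0.22 log units; that floor lies within the scatter), modest in size and toward a lower number. For compound 3 the estimated value is 120000 nM, with an expected range of 60000 nM to 200000 nM.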

Compound 3, half-maximal inhibitory concentration: 57000 nM
Compound 3: the middle estimate sits 2.1-fold (0.32 log units) above what was measured, and the stated range ends above it.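

In this assay, the 3-bromophenyl group gives an at least 3.5-fold lower number from compound 2 to compound 3 (0.54 log units; beyond the scatter), so at this ring carbon the exchange of methoxy for bromo moves the read-out beyond the scatter, which the earlier step, with its floor inside the scatter, could not show. Compound 2 stands at a limit of the assay and not a number, so the size of this step remains a floor: the limit of > 200000 nM in this assay, at which 1 of the 3 values shown sits.

The two halogen-bearing compounds also separate, with a 2.1-fold lower number from compound 1 to compound 3 (0.31 log units; beyond the scatter), so carrying a halogen does not by itself fix the number, although that step changes both the halogen and its place on the ring. Going by these compounds, what a 3-chlorophenyl or a 4-bromophenyl group would give remains open, so the effect of the halogen cannot yet be told apart from that of its place. Also open, on these data alone, is how an amine or a carboxylic acid at this ring carbon would read in this assay.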